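Bromo substitution on the fused indoline series

A few compounds are considered here, and "the series" means these few. Any claim that something is new, unique, unknown or untested is made for them only; others in the source may bear on it.

Three compounds of this series have been run in a functional assay on HeLa cells (Homo sapiens) for inhibition, read by sulforhodamine B assay, with a stated time of 48 h; a lower number here means a stronger inhibitor of growth, a higher number a weaker inhibitor of growth. Compound 1 `COC(=O)[C@@]1(C)CCC=C2[C@@H]1CC[C@@H](C)[C@]2(C)Cc1c[nH]c2c(Br)cccc12` gives 13000 nM in this assay. Compound 2 `COC(=O)[C@@]1(C)CCC=C2[C@@H]1CC[C@@H](C)[C@]2(C)Cc1c(C)[nH]c2ccccc12` gives 11000 nM in this assay. Compound 3 `COC(=O)[C@@]1(C)CC[C@@H]2C3=C1CC[C@@H](C)[C@]3(C)C[C@@H]1c3ccccc3N[C@H]21` gives 19000 nM in this assay. Compound 3 thus carries the highest number of the three, but its gaps to compound 1 and to compound 2 are both within the usual scatter of repeated measurements, so no order among the three can be read from these values.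

The next member, compound 4 `COC(=O)[C@@]1(C)CC[C@@H]2C3=C1CC[C@@H](C)[C@]3(C)C[C@@H]1c3cc(Br)ccc3N[C@H]21`, keeps the core of compound 3 and differs from it in one place: bromo in place of hydrogen on an aromatic carbon. Among the measured compounds shown here, no step between measured compounds of this kind is available for comparison; compound 1 also carries a bromo group, but on a different core, and its value next to that of compound 2 says nothing about a step within the core of compound 3.

With nothing to anchor a direction, the step from compound 3 to compound 4 is expected to be small, a 1.3-fold lower number from compound 3 to compound 4 (0.10 log units; within the scatter), and not beyond the scatter. Compound 4 is therefore estimated at 15000 nM in this assay, with a range from 6000 nM to 40000 nM.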

Compound 4, concentration for 50% growth inhibition: 25000 nM
Compound 4: middle estimate off by 1.7-fold (0.22 log units), on the low side; the measured number falls inside the stated range.
By their numbers in this assay, from the lowest: compounds 2, 1, 3 and 4 (each within the scatter of the next, the first and the last beyond it).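

In this assay the core of compound 3 now has its first readable step, with bromo in place of hydrogen on an aromatic carbon giving a 1.3-fold higher number from compound 3 to compound 4 (0.12 log units; within the scatter) and therefore no change that can be told from the scatter. Among the compounds shown here, at this carbon, para to a fused ring and meta to a fused ring, the added bromine atom is thus accommodated with the growth-inhibition read-out staying within the scatter, something the earlier compounds could not show because none of them formed a step within a single core. No supporting data bear on this result, so the step stands as an observation without an explanation.

From the compounds shown here alone, whether an amine, a carboxylic acid or a methoxy group on this same aromatic carbon would give a step beyond the scatter remains open, and a single halogen does not settle how far the position tolerates larger or more polar groups. Also open, going by these compounds, is whether bromo on the other aromatic carbons of this ring would give a step of the same size, and whether chloro or fluoro at this position would match bromo.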